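Formyl Instead of Bromo Lifts a Fused Core into Range

This account rests on a few compounds, and the source may have more. Where it says the series, first, only, none or still open, it means among the compounds named here.

The series is followed in a functional assay on L1210 cells (Mus musculus) for cytotoxicity, with a stated time of 48 h; a lower number here means a stronger inhibitor, a higher number a weaker inhibitor. Compound 1 `Clc1ccc(Cc2nn3c(Br)c(-c4ccc(Cl)cc4)nc3s2)cc1` gives only a limit of the assay in this assay, > 250000 nM. Compound 2 `Clc1ccc(Cc2nn3c(Br)c(-c4ccc(Br)cc4)nc3s2)cc1` likewise gives only a limit of the assay in this assay, > 250000 nM. Between them stands the change (bromo in place of chloro on an aromatic carbon), and the two limits leave the step that the two limits leave unreadable from compound 1 to compound 2 unreadable. Going by the values given here, compound 3 `O=Cc1c(-c2ccc(Cl)cc2)nc2sc(Cc3ccc(Cl)cc3)nn12` is the one member with a number in this assay: compound 3 gives 15000 nM. The cores of compound 1 and compound 3 differ by formyl in place of bromo on an aromatic carbon, and this gives the step of an at least 16-fold lower number from compound 1 to compound 3 (1.22 log units; beyond the scatter); that it can be read only as a lower bound rests on (the limit of > 250000 nM in this assay, at which 2 of the 3 values shown sit).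

Compound 4 `O=Cc1c(-c2ccc(Br)cc2)nc2sc(Cc3ccc(Cl)cc3)nn12` remains to be measured in this assay. It differs from compound 3 by bromo in place of chloro on an aromatic carbon, and the place of the change reads word for word as it does for compound 1 and compound 2, so this is the same change, made here on a core that already carries the formyl group. The step is expected to be no change at the digits printed from compound 3 to compound 4 (within the scatter), since the step that the two limits leave unreadable from compound 1 to compound 2 is not readable and the halogen pair sits away from the place where compound 3 separated from compound 1. Compound 4 is therefore estimated at 15000 nM, expected within 5000 nM to 45000 nM.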

Compound 4, half-maximal inhibitory concentration: 4600 nM
Estimate against measurement, compound 4: 3.3-fold (0.51 log units) above; measured number outside the range, below it.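

Going by these compounds alone, with compound 4 measured, the bromo for chloro change can be read for the first time, and on the core that carries the formyl group it gives a 3.3-fold lower number from compound 3 to compound 4 (0.51 log units; beyond the scatter) in this assay. The formyl for bromo change now stands on a second core with an at least 54-fold lower number from compound 2 to compound 4 (1.73 log units; beyond the scatter), so a lower number follows this change on both cores shown, though its size on each is only a lower bound: the same change on two cores in this assay, an at least 16-fold lower number (1.22 log units; beyond the scatter) from compound 1 to compound 3 and an at least 54-fold lower number (1.73 log units; beyond the scatter) from compound 2 to compound 4; the limit leaves it open whether they differ. The bromo for chloro change cannot be followed from one core to the other, as its step on the bromo-bearing core cannot be read, and no size for the formyl change can be given on either core, as both steps start from a limit of the assay: the limit of > 250000 nM in this assay, at which 2 of the 4 values shown sit.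

The compounds shown leave open whether the formyl group itself is needed, or whether a nitrile, a carboxylic acid or a hydroxymethyl group at that place would give a similar number. They also leave open how far the 4-chlorophenyl to 4-bromophenyl step extends on the formyl core, for instance to an iodo group or an amine on that ring.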